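The source may report more compounds than this note shows. Statements on the series, on what has been measured and on what is new or still open speak of the compounds shown alone.

Three compounds of this series have been run in a functional assay on A549 cells (Homo sapiens) for cytotoxicity, read by resazurin assay, with a stated time of 48 h; on this read-out higher numbers stand for weaker inhibition and lower numbers for stronger inhibition. Among the compounds with values here, compound 1 `C=CCOC(=O)NC[C@H]1OC(N(CC2=CC[C@@H](C(=C)C)CC2)OC)[C@H](O)[C@@H](O)[C@@H]1O` gives 140000 nM, and compound 3 `C=C(C)[C@@H]1CC=C(CN(OC)C2O[C@H](CN=[N+]=[N-])[C@@H](O)[C@H](O)[C@H]2O)CC1` gives 163000 nM; the one measured step, a 1.2-fold higher number from compound 1 to compound 3 (0.07 log units; within the scatter), concerns a change of group, not of configuration. Compound 2 `C=C(C)[C@@H]1CC=C(CN(OC)C2O[C@@H](CO)[C@H](N=[N+]=[N-])[C@@H](O)[C@@H]2O)CC1` gives 451000 nM, the highest of the three numbers, with compound 3 nearest and compound 1 furthest, both beyond the scatter. Compound 4 `C=C(C)[C@@H]1CC=C(CN(OC)C2O[C@H](CO)[C@@H](N=[N+]=[N-])[C@H](O)[C@H]2O)CC1` has not yet been measured. It differs from compound 2 only in configuration: the two compounds have the same atoms and bonds; at least one stereo element is drawn with a configuration in one of them and without one in the other: 4 of 7 stereo elements differ; a stereocentre at a saturated ring carbon is drawn R in compound 2 and S in compound 4; a stereocentre at a saturated ring carbon is drawn R in compound 2 and S in compound 4; a stereocentre at a saturated ring carbon is drawn R in compound 2 and S in compound 4; a stereocentre at a saturated ring carbon is drawn S in compound 2 and R in compound 4. Within the data shown here, no measured step here changes a stereocentre, so the data give no size for such a change. The expected step is a 1.1-fold lower number from compound 2 to compound 4 (0.05 log units; within the scatter), with no direction beyond the scatter. Compound 4 is estimated at 400000 nM, between 150000 nM and 1000000 nM.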

Compound 4, half-maximal inhibitory concentration: 4000 nM
Compound 4: the middle estimate sits 100-fold (2.00 log units) above what was measured, and the stated range ends above it.
By their numbers in this assay, from the lowest: compound 4; then compounds 1 and 3 (each within the scatter of the next); then compound 2.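

In this assay, configuration alone moves the number: with the same atoms and bonds, the step is a 110-fold lower number from compound 2 to compound 4 (2.05 log units; beyond the scatter). Within the data shown here, the only earlier step, a change of group, stayed within the scatter, so these compounds are the first to show that the stereocentres at saturated ring carbons can matter. One reservation attaches to this step: the fact that one of compounds 2 and 4 is drawn with a defined configuration and the other without, at the place where they differ

The compounds shown leave open which of the differing stereocentres carries the step. They also leave open whether compound 4 would keep its number with an amine in place of azido.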